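The source may report more compounds than this note shows. Statements on the series, on what has been measured and on what is new or still open speak of the compounds shown alone.

The series shares one core and varies only the aryl group on the outer ring. Compound 1 `Oc1ccccc1/C=N/c1nnc(SCc2nnc(-c3ccc(F)cc3)o2)s1` gives in a functional assay on A549 cells (Homo sapiens) for inhibition, read by CCK-8 assay (a higher number here means a weaker inhibitor, a lower number a stronger inhibitor), a value of 20100 nM. Compound 2 `Oc1ccccc1/C=N/c1nnc(SCc2nnc(-c3ccccc3Cl)o2)s1` gives in this assay 18100 nM, and compound 3 `Oc1ccccc1/C=N/c1nnc(SCc2nnc(-c3ccc(Br)cc3)o2)s1` gives 20000 nM. The three numbers sit within the scatter of one another: a 1.0-fold lower number from compound 1 to compound 3 (0.00 log units; within the scatter), a 1.1-fold higher number from compound 2 to compound 3 (0.04 log units; within the scatter), and a 1.1-fold lower number from compound 1 to compound 2 (0.05 log units; within the scatter). Compound 3 cannot be told apart from compound 1 or from compound 2 on this measure.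

Compound 4 `Cc1ccc(-c2nnc(CSc3nnc(/N=C/c4ccccc4O)s3)o2)cc1` is not yet measured. It differs from compound 3 by methyl in place of bromo on an aromatic carbon. The measured steps that bear on this are the exchanges of the aryl substituent already made: a 1.0-fold lower number from compound 1 to compound 3 (0.00 log units; within the scatter) swapped one halogen for another at the same position with no effect beyond the scatter, and a 1.1-fold higher number from compound 2 to compound 3 (0.04 log units; within the scatter) replaced a 2-chlorophenyl by a 4-bromophenyl with the same outcome. Going by the values given here, nothing measured so far separates any aryl variant from the rest. A methyl at this position is therefore expected to leave the number essentially where it stands, a 1.1-fold lower number from compound 3 to compound 4 (0.02 log units; within the scatter), within the scatter. Compound 4 is estimated at 19000 nM, with a range from 9000 nM to 40000 nM.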

Compound 4, half-maximal inhibitory concentration: 22000 nM
For compound 4 the middle estimate is 1.2-fold (0.06 log units) below the measured one; low and high end bracket the measured number.
By their numbers in this assay, from the lowest: compounds 2, 3, 1 and 4 (each within the scatter of the next).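

Going by these compounds alone, compound 1, compound 2 and compound 3 all carry a halogen on the aryl ring, so compound 4 is the first case here with a carbon substituent at this place, para to a large group. In this assay, the change from 4-bromophenyl to 4-methylphenyl gives a 1.1-fold higher number from compound 3 to compound 4 (0.04 log units; within the scatter), and the exchange of fluoro for methyl gives a 1.1-fold higher number from compound 1 to compound 4 (0.04 log units; within the scatter), so within these compounds the response at this position does not depend on a halogen being present. The comparison across a different substitution place, a 1.2-fold higher number from compound 2 to compound 4 (0.08 log units; within the scatter), also stays inside the scatter, leaving all four aryl variants unseparated with no compound going against this, and no available data offer an explanation for this flat response.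

Still open, on these data alone, is whether this insensitivity extends to groups of a different kind on the same ring, such as an amine, a carboxylic acid or a longer alkyl chain. The compounds shown also leave untested any change outside the aryl group, so what in the shared core governs the number in this assay remains unknown.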